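Methylsulfonyl in Place of Hydrogen on Compound 1

A few compounds are considered here, and "the series" means these few. Any claim that something is new, unique, unknown or untested is made for them only; others in the source may bear on it.

In a functional assay on HO8910 cells (Homo sapiens) for cytotoxicity, read by CCK-8 assay, with a stated time of 24 h (on this read-out lower numbers stand for stronger inhibition and higher numbers for weaker inhibition), compound 1 `C/C(=C\c1cc(-c2ccccc2)cs1)C(N)=O` gives a reading of > 50000 nM, which is a limit of the assay rather than a number. Compound 1 therefore stands at the weak end of the three values shown, sitting at the limit of > 50000 nM in this assay, at which 1 of the 3 values shown sits. Compound 3 `C/C(=C\c1cc(-c2ccccc2C)cs1)C(N)=O` gives 15200 nM in this assay, while compound 2 `C/C(=C\c1cccc(-c2ccc(C)cc2)c1)C(N)=O`, built on a different core, gives 26800 nM.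

Compound 4 `C/C(=C\c1cc(-c2ccc(S(C)(=O)=O)cc2)cs1)C(N)=O` differs from compound 1 by methylsulfonyl in place of hydrogen on an aromatic carbon, the new group sitting on a six-membered aromatic ring of carbon only, para to a large group.

Among the measured compounds shown here, only one measured step bears on this change: an at least 3.2-fold lower number from compound 1 to compound 3 (0.51 log units; beyond the scatter). That step adds a far smaller group than methylsulfonyl, so it is no more than a loose guide, and since compound 1 is known only as a limit, the true size of that gain is open beyond its floor. One would therefore expect for compound 4 in this assay a step of an at least 1.4-fold lower number from compound 1 to compound 4 (0.15 log units; that floor lies within the scatter), a modest improvement at most, with a real chance that the assay again reports only a limit. The estimate for compound 4 is 35000 nM, with an expected range from 10000 nM to 100000 nM.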

Compound 4, half-maximal inhibitory concentration: > 50000 nM
Compound 4 gave a limit, no number; the forecaster's own chance of this, stated with the estimate: 45%; at least 1.4-fold (0.15 log units) between middle value and limit.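

In this assay compound 4 gives > 50000 nM, which is a limit of the assay and not a number. With compound 1 also known only as a limit, no step between the two can be read, and both sit at the same place: the limit of > 50000 nM in this assay, at which 2 of the 4 values shown sit.

What the compounds shown leave open is whether methylsulfonyl in place of hydrogen on an aromatic carbon changes the reading at all, and in which direction.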